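Pyrazin-2-yl in place of pyridin-4-yl: an expected solubility

This account rests on a few compounds, and the source may have more. Where it says the series, first, only, none or still open, it means among the compounds named here.

Measured in a physicochemical assay for solubility, in phosphate buffer, with a stated time of 18 h; on this read-out lower numbers stand for lower solubility and higher numbers for higher solubility:
- compound 1 `CC(C)(C)c1nc(CCCCCC#N)c2c(N)c(C#N)c(N)nc2n1`: 6000 nM
- compound 2 `CC(C)(C)c1nc(-c2cccs2)c2c(N)c(C#N)c(N)nc2n1`: 56000 nM
- compound 3 `CC(C)(C)c1nc(-c2ccncc2)c2c(N)c(C#N)c(N)nc2n1`: 44000 nM

Compound 3 belongs to the upper pair of these numbers. The lowest number belongs to the compound with the 5-cyanopentyl group: a 7.3-fold higher number from compound 1 to compound 3 (0.87 log units; beyond the scatter). The next compound, compound 4 `CC(C)(C)c1nc(-c2cnccn2)c2c(N)c(C#N)c(N)nc2n1`, carries pyrazin-2-yl in place of pyridin-4-yl on an aromatic carbon. Within the data shown here, the closest precedent is one aromatic ring exchanged for another: a 1.3-fold lower number from compound 2 to compound 3 (0.10 log units; within the scatter). The other measured step, a 9.3-fold higher number from compound 1 to compound 2 (0.97 log units; beyond the scatter), removes the 5-cyanopentyl group, which does not happen here. So no step beyond the scatter is expected in this assay. The expected change is a 1.0-fold lower number from compound 3 to compound 4 (0.02 log units; within the scatter). The estimate for compound 4 is 42000 nM, with an expected range from 17000 nM to 100000 nM.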

Compound 4, solubility: 86000 nM
Compound 4: the middle estimate sits 2.0-fold (0.31 log units) below what was measured, within the range that was stated.
By their numbers in this assay, from the lowest: compound 1; then compounds 3, 2 and 4 (each within the scatter of the next).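

In this assay, pyrazin-2-yl on this aromatic carbon cannot be told apart from the two other aromatic rings, with a 2.0-fold higher number from compound 3 to compound 4 (0.29 log units; within the scatter) and a 1.5-fold higher number from compound 2 to compound 4 (0.19 log units; within the scatter). The 5-cyanopentyl group remains the one that stands apart, with a 14-fold higher number from compound 1 to compound 4 (1.16 log units; beyond the scatter), the largest step among these compounds. No measurement here explains these numbers.

The compounds shown leave open whether an amine or a shorter alkyl chain in this place would give numbers like those of the aromatic rings or like that of compound 1.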